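Swapping Methyl for Chloro on the Benzoyl Arm

The source may report more compounds than this note shows. Statements on the series, on what has been measured and on what is new or still open speak of the compounds shown alone.

In an ADME assay on HEK-293T cells (Homo sapiens) for cytotoxicity, read by MTT assay, with a stated time of 24 h (on this read-out lower numbers stand for higher toxicity in this test and higher numbers for lower toxicity in this test), compound 1 `Cc1ccc(C(=O)n2c(-c3cn(-c4ccccc4)nc3-c3ccc(F)cc3)nc3ccccc32)cc1` gives 178000 nM. Two close relatives were run in the same test: compound 2 `Cc1ccc(-c2nn(-c3ccccc3)cc2-c2nc3ccccc3n2C(=O)c2ccccc2)cc1` gives 204000 nM and compound 3 `Cc1ccc(-c2nn(-c3ccccc3)cc2-c2nc3ccccc3n2C(=O)c2cccc(C)c2)cc1` gives 195000 nM, so all three numbers sit within the usual scatter of one another, and compound 1 cannot be set apart from either. The only single-point step among these compounds, a 1.0-fold lower number from compound 2 to compound 3 (0.02 log units; within the scatter), shifted the number by less than the scatter. Compound 4 `O=C(c1ccc(Cl)cc1)n1c(-c2cn(-c3ccccc3)nc2-c2ccc(F)cc2)nc2ccccc21` differs from compound 1 by chloro in place of methyl on an aromatic carbon. Among the compounds with values here, no measured pair shows this exact exchange; the one step at hand also placed a group on an aromatic carbon and left the read-out essentially where it was. The expectation is therefore no step beyond the scatter, a 1.0-fold higher number from compound 1 to compound 4 (0.00 log units; within the scatter). Compound 4 is estimated at 180000 nM, between 90000 nM and 360000 nM.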

Compound 4, half-maximal cytotoxic concentration: 179000 nM
The estimate for compound 4 lay 1.0-fold (0.00 log units) above the measured number; the range from low to high includes it.
By their numbers in this assay, from the lowest: compounds 1, 4, 3 and 2 (each within the scatter of the next).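

Chloro in place of methyl, para to a large group on the benzoyl arm, gives a 1.0-fold higher number from compound 1 to compound 4 (0.00 log units; within the scatter) in this assay. Within the data shown here, this is the first direct test of this position, and at this position the read-out does not separate 4-methylphenyl from 4-chlorophenyl. No measurement here offers an explanation for this. As far as these compounds go, it remains open whether an amine or a carboxylic acid at this position would also stay within the scatter of compound 1.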